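Swapping hydroxy for carbamoyl: a small step expected

The source may hold more compounds than are shown below. What is called first, only, known or untested is meant among the compounds shown, and "the series" means these compounds.

Compound 1 `COc1ccc(/C=C2\c3cc(OC)c(OC)c(OC)c3CC[C@@H]2O)cc1C(N)=O` gives 550 nM
Compound 2 `COc1ccc(/C=C2\c3cc(OC)c(OC)c(OC)c3CC[C@H]2O)cc1C#N` gives 200 nM
Compound 3 `COc1ccc(/C=C2\c3cc(OC)c(OC)c(OC)c3CC[C@H]2O)cc1O` gives 790 nM

All three share one core and were tested in a functional assay on HT-29 cells (Homo sapiens) for inhibition, read by MTT assay (on this read-out lower numbers stand for stronger inhibition and higher numbers for weaker inhibition), on the same read-out. Compound 3 (790 nM) cannot be told apart from compound 1 (550 nM) within the scatter. Compound 2 (200 nM) gives a clearly lower number, which means stronger inhibition.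

The next compound is compound 4 `COc1ccc(/C=C2\c3cc(OC)c(OC)c(OC)c3CC[C@H]2O)cc1C(N)=O`, which has carbamoyl in place of hydroxy on an aromatic carbon of compound 3 (carbamoyl in place of hydroxy on an aromatic carbon). This carbon lies ortho to a methoxy group.

Going by the values given here, one measured step touches the same carbon: a 4.0-fold higher number from compound 2 to compound 3 (0.60 log units; beyond the scatter) with hydroxy in place of cyano. It is modest, but it shows that a swap here can move the number beyond the scatter. Compound 1 (550 nM) already carries carbamoyl, but with the opposite spatial arrangement at the hydroxy-bearing carbon of the core, so it is only a loose guide. Among the compounds with values here, no measurement yet shows carbamoyl with the arrangement found in compound 3.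

A small move towards a lower number is therefore expected, and the estimated step is a 1.8-fold lower number from compound 3 to compound 4 (0.24 log units; within the scatter) as a best guess. For compound 4 the expected value is 450 nM within an estimated range from 150 nM to 1300 nM in this assay.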

Compound 4, half-maximal inhibitory concentration: 550 nM
Compound 4: the middle estimate sits 1.2-fold (0.09 log units) below what was measured, and the stated range covers the measured number.
By their numbers in this assay, from the lowest: compound 2; then compounds 1, 4 and 3 (each within the scatter of the next).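

In this assay, carbamoyl and hydroxy on this aromatic carbon cannot be told apart, with a 1.4-fold lower number from compound 3 to compound 4 (0.16 log units; within the scatter). Among the groups shown at this carbon, cyano alone stands out, since carbamoyl also gives weaker inhibition than cyano, with a 2.8-fold higher number from compound 2 to compound 4 (0.44 log units; beyond the scatter), just as hydroxy does. The spatial arrangement at the hydroxy-bearing carbon of the core, which made compound 1 only a loose guide, makes no difference that can be read in the carbamoyl pair, with no change at the digits printed from compound 1 to compound 4 (within the scatter), and this comparison tests that arrangement alone because of one fact: the fact that compounds 1 and 4 differ only in the configuration as drawn.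

Whether the two arrangements also match when cyano sits on this aromatic carbon stays open, as the one pair shown in both arrangements carries carbamoyl. Going by these compounds, it also stays open how an amine or a carboxylic acid on this carbon would compare with cyano in this assay, and so whether cyano is a rare good fit here or one of several groups that give stronger inhibition.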